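Carboxylic acid, benzylamide, and a hydrazide on a shared core

The source may hold more compounds than are shown below. What is called first, only, known or untested is meant among the compounds shown, and "the series" means these compounds.

Measured so far:
compound 1 `Nc1sc2c(c1C(=O)O)CCN(Cc1ccccc1)C2` — 8000 nM
compound 2 `Nc1sc2c(c1C(=O)NCc1cccc(Cl)c1)CCN(Cc1ccccc1)C2` — > 20000 nM

In an in vitro assay on CHOk1 cells with adenosine receptor A1 (Homo sapiens) as the target (on this read-out lower numbers stand for an effect already at smaller amounts and higher numbers for an effect only at larger amounts of compound), compound 1 gives 8000 nM. Compound 2 sits at a limit of this assay, > 20000 nM, so its true position is open (the limit of > 20000 nM in this assay, at which 1 of the 2 values shown sits). Within the data shown here, the only measured step is an at least 2.5-fold higher number from compound 1 to compound 2 (0.39 log units; beyond the scatter), hydroxy to (3-chlorobenzyl)amino on the carbonyl carbon. Compound 3 `NNC(=O)c1c(N)sc2c1CCN(Cc1ccccc1)C2` differs from compound 2 by amino in place of 3-chlorobenzyl on an amide-type nitrogen. That change removes most of what the measured step added, so a move back toward compound 1 seems plausible, though compound 2 standing at a limit leaves the size uncertain. Compound 3 is expected at 15000 nM, range 5000 nM to 50000 nM, an expected step of an at least 1.3-fold lower number from compound 2 to compound 3 (0.12 log units; that floor lies within the scatter).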

Compound 3, half-maximal effective concentration: 8900 nM
For compound 3 the middle estimate is 1.7-fold (0.23 log units) above the measured one; the measured number falls inside the stated range.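

In this assay, amino in place of 3-chlorobenzyl on the amide-type nitrogen gives an at least 2.2-fold lower number from compound 2 to compound 3 (0.35 log units; beyond the scatter), so the higher number of compound 2 does not extend to every amide-type group on this carbonyl carbon. Compound 2 stands at a limit, > 20000 nM, so this step gives only a floor. Aminoamino in place of hydroxy gives a 1.1-fold higher number from compound 1 to compound 3 (0.05 log units; within the scatter), so these two groups are not told apart at this position.

Open, going by these compounds, is how a methyl or an unsubstituted benzyl on that nitrogen would read, and whether the chlorine of the 3-chlorobenzyl group plays any part.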